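Swapping one halophenyl for another on an inactive core

The source may report more compounds than this note shows. Statements on the series, on what has been measured and on what is new or still open speak of the compounds shown alone.

Three compounds that share one core have been run in a functional assay on the whole organism (strain Swiss) with Mus musculus as the target, in the maximal electroshock model, with a stated time of 1 h, at a dose of 100 mg/kg by the intraperitoneal route; a higher number here means a stronger effect of the compound at the dose given, a lower number a weaker effect. Compound 1 `CC(C(=O)N1CCN(c2ccccc2F)CC1)N1C(=O)CCC1=O` gives 0%. Compound 2 `CCC(C(=O)N1CCN(c2ccccc2F)CC1)N1C(=O)CCC1=O` carries methyl in place of hydrogen on a saturated chain carbon and gives 0%. Compound 3 `CC(C(=O)N1CCN(c2cccc(F)c2)CC1)N1C(=O)CCC1=O` carries 3-fluorophenyl in place of 2-fluorophenyl and gives 0%. Both measured steps, no change at the digits printed from compound 1 to compound 2 (within the scatter) and no change at the digits printed from compound 1 to compound 3 (within the scatter), leave the read-out where it was, so compound 2 stands level with compounds 1 and 3, and none of the three shows an effect at the dose used.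

Compound 4 `CCC(C(=O)N1CCN(c2cccc(Cl)c2)CC1)N1C(=O)CCC1=O` has not yet been measured. It differs from compound 2 in one place: 3-chlorophenyl in place of 2-fluorophenyl on an amine nitrogen in a ring. The step from compound 1 to compound 3 bears on this most, since it also exchanges one fluorophenyl for another on the same ring nitrogen, and it was flat. Among the compounds with values here, the exchange of fluorine for chlorine on that phenyl has no measured counterpart here. With a flat record on every side, the step is expected to be no change beyond the scatter, no change at the digits printed from compound 2 to compound 4 (within the scatter). Compound 4 is therefore estimated at 0%, with a range from 0% to 25%.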

Compound 4, a percentage reported as activity, at one dose (the size of the read-out at that dose, not a potency): 0%
Estimate against measurement, compound 4: no gap at the digits printed; the range from low to high includes it.
By their numbers in this assay, from the lowest: compounds 1, 2, 3 and 4 (each within the scatter of the next).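

In this assay putting 3-chlorophenyl in place of 2-fluorophenyl on the amine nitrogen in the ring gives no change at the digits printed from compound 2 to compound 4 (within the scatter) and so adds a chlorine-bearing phenyl to the two fluorophenyls already on record at this position, now on the core of compound 2 with its added methyl. This single step changes both the halogen and its place on the phenyl, so the two changes cannot be told apart, and a read-out that stays at nothing cannot show whether either change would weaken an effect. Nothing available here bears on why the read-out stays flat across these compounds.

Every compound shown carries a phenyl with one halogen on that nitrogen, so it remains open whether a plain phenyl, a benzyl or a phenyl bearing trifluoromethyl there would give any effect at this dose. Going by these compounds, it also remains open whether a longer chain, or an amine on the chain carbon, would lift the read-out above nothing.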